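The source may report more compounds than this note shows. Statements on the series, on what has been measured and on what is new or still open speak of the compounds shown alone.

Compound 1 `C=C(c1ccccc1)c1cccc(N(Cc2cccnc2)S(=O)(=O)CC)c1`: in an assay on isolated protein with metabotropic glutamate receptor 2 (Homo sapiens) as the target (on this read-out lower numbers stand for an effect already at smaller amounts and higher numbers for an effect only at larger amounts of compound), compound 1 gives 200 nM.
Compound 2 `CCS(=O)(=O)N(Cc1cccnc1)c1ccc(C(F)c2ccccc2)cc1`: in this assay compound 2 reaches only > 30000 nM, which is a limit of the assay and not a number.
Compound 3 `CCS(=O)(=O)N(Cc1cccnc1)c1ccc(COc2ccccc2)cc1`: in this assay compound 3 gives 2100 nM.

Of the two numbers in hand, compound 1 holds the lowest, and compound 3 stands above it by a margin beyond the scatter. The value of compound 2 sits at the limit of > 30000 nM in this assay, at which 1 of the 3 values shown sits, so it adds no number of its own.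

Among the measured compounds shown here, only one measured step exists, an at least 14-fold lower number from compound 2 to compound 3 (1.15 log units; beyond the scatter). It shows that phenoxymethyl is well tolerated, but it starts from a different group and a different place, so it speaks only indirectly to the case at hand.

Compound 4 `CCS(=O)(=O)N(Cc1cccnc1)c1cccc(COc2ccccc2)c1` differs from compound 1 by phenoxymethyl in place of 1-phenylethenyl on an aromatic carbon. The shared core and the meta placement are kept; what changes is the group itself. For the measured compounds named here, since phenoxymethyl gave a higher number than the one seen for compound 1 wherever it has been measured, compound 4 is expected to show a 3.0-fold higher number from compound 1 to compound 4 (0.48 log units; beyond the scatter) in this assay, a rise of moderate size rather than a loss to the limit. Compound 4 is therefore estimated at 600 nM, with a range from 150 nM to 2500 nM.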

Compound 4, half-maximal effective concentration: 160 nM
For compound 4 the middle estimate is 3.8-fold (0.57 log units) above the measured one; the measured number falls inside the stated range.
By their numbers in this assay, from the lowest: compounds 4 and 1 (each within the scatter of the next); then compound 3. At a limit, above all of these: compound 2.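

At this position, on an aromatic carbon meta to a large group, the two eight-atom groups prove interchangeable in this assay: the data show a 1.3-fold lower number from compound 1 to compound 4 (0.10 log units; within the scatter), so the double bond outside aromatic rings can leave and a hydrogen-bond acceptor can enter with no change that stands out from the scatter. Earlier, phenoxymethyl was known only from compound 3 at 2100 nM, and compound 4 at 160 nM shows that this value does not carry over to the present position, so the group's place on the ring matters as well as its identity. The data shown give no measured property that would explain why the two groups match here.

Going by these compounds, it remains open how far this position accepts other groups, such as an amine or a carboxylic acid on the outer phenyl ring, or a longer chain in place of the methylene link of phenoxymethyl. Among the compounds shown here, it is also open whether fluoro(phenyl)methyl would fare better at this position than at the one it occupies in compound 2.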